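The source may hold more compounds than are shown below. What is called first, only, known or untested is meant among the compounds shown, and "the series" means these compounds.

Two compounds share one core and differ only in the group on a saturated chain carbon bound to an aromatic carbon. Compound 1 `COc1cc(Oc2cccc(Nc3ccccc3)c2)cc(OC)c1CNC(C)C` carries an isopropylamino group there; in a functional assay on HCT-15 cells (Homo sapiens) for inhibition, read by MTT assay, with a stated time of 72 h (a higher number here means a weaker inhibitor, a lower number a stronger inhibitor), compound 1 gives only a limit, > 20000 nM, not a number. Compound 2 `COc1cc(Oc2cccc(Nc3ccccc3)c2)cc(OC)c1CN(C)C` carries a dimethylamino group; in this assay compound 2 gives 15600 nM, which is the only number shown. The other value, that of compound 1, is a limit (the limit of > 20000 nM in this assay, at which 1 of the 2 values shown sits). Going by the values given here, the one measured step, an at least 1.2-fold lower number from compound 1 to compound 2 (0.10 log units; that floor lies within the scatter), is therefore only a floor and says little about how much this position matters. Compound 3 `COc1cc(Oc2cccc(Nc3ccccc3)c2)cc(OC)c1CCO` is the next change: hydroxymethyl in place of dimethylamino on a saturated chain carbon bound to an aromatic carbon. Among the compounds with values here, no measured step covers replacing dimethylamino with hydroxymethyl, so the step of a 1.3-fold higher number from compound 2 to compound 3 (0.11 log units; within the scatter) is expected to be small and of uncertain direction. Compound 3 is expected to give about 20000 nM, between 6000 nM and 60000 nM.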

Compound 3, half-maximal inhibitory concentration: 12100 nM
Estimate against measurement, compound 3: 1.7-fold (0.22 log units) above; measured number inside the range.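

In this assay, going by these compounds alone, the step is a 1.3-fold lower number from compound 2 to compound 3 (0.11 log units; within the scatter), and this is the first comparison at this position between two actual numbers rather than against a limit. Dimethylamino, with no hydrogen-bond donor, and hydroxymethyl, with one, cannot be told apart in this assay, so on a saturated chain carbon bound to an aromatic carbon, this change of nitrogen for oxygen leaves the result unmoved within the scatter. Compound 1 still has only a limit, not a number, so an at least 1.6-fold lower number from compound 1 to compound 3 (0.21 log units; that floor lies within the scatter) is no more than a floor: the limit of > 20000 nM in this assay, at which 1 of the 3 values shown sits.

On these data alone, how far compound 1 truly lies from the other two remains open. So does whether a carboxylic acid, a morpholine ring or a longer chain at this position would shift the number beyond the scatter.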